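The source may hold more compounds than are shown below. What is called first, only, known or untested is meant among the compounds shown, and "the series" means these compounds.

In a functional assay on HepG2 cells (Homo sapiens) for inhibition, read by MTT assay, with a stated time of 48 h (on this read-out higher numbers stand for weaker inhibition and lower numbers for stronger inhibition), compound 1 `COc1ccc(/C=C2\SC(=O)N(CC(=O)Nc3c(C)n(C)n(-c4ccccc4)c3=O)C2=O)cc1` gives 68500 nM, while compound 2 `Cc1c(NC(=O)CN2C(=O)S/C(=C\c3ccc(Br)cc3)C2=O)c(=O)n(-c2ccccc2)n1C` gives 19200 nM, the lower of the two numbers. Compound 3 `Cc1c(NC(=O)CN2C(=O)S/C(=C\c3ccc(Cl)cc3)C2=O)c(=O)n(-c2ccccc2)n1C` differs from compound 2 by chloro in place of bromo on an aromatic carbon, para to a large group. For the measured compounds named here, the only measured step bearing on this is a 3.6-fold lower number from compound 1 to compound 2 (0.55 log units; beyond the scatter), with bromo in place of methoxy on the same aromatic carbon. Being modest, it suggests no change beyond the scatter in this assay is to be expected here. The estimated change is a 1.3-fold higher number from compound 2 to compound 3 (0.10 log units; within the scatter). For compound 3 the expected value is 24000 nM, with an estimated range of 11000 nM to 50000 nM.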

Compound 3, half-maximal inhibitory concentration: 31900 nM
Compound 3: middle estimate off by 1.3-fold (0.12 log units), on the low side; measured number inside the range.
By their numbers in this assay, from the lowest: compounds 2 and 3 (each within the scatter of the next); then compound 1.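

In this assay, chloro in place of bromo on this aromatic carbon, para to a large group, gives no separable change (a 1.7-fold higher number from compound 2 to compound 3 (0.22 log units; within the scatter)), so the two halogens cannot be told apart here. Chloro in place of methoxy (a 2.1-fold lower number from compound 1 to compound 3 (0.33 log units; beyond the scatter)) shows that compound 1 is also separated from a second halogen compound, though only modestly. No available evidence explains these numbers. What the compounds shown leave open is how fluoro, an amine or a carboxylic acid on this carbon would read. They also leave open whether the same order holds with a different group on the core.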